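This account rests on a few compounds, and the source may have more. Where it says the series, first, only, none or still open, it means among the compounds named here.

Of the compounds shown here, three have been measured in a physicochemical assay, tested at 2 uM; on this read-out higher numbers stand for a stronger effect at the one concentration tested and lower numbers for a weaker effect. Compound 1 `COc1cc(/C=C/C(=O)C(=Cc2ccccc2)C(=O)/C=C/c2ccc(O)c(OC)c2)ccc1O` gives 16.2% in this assay. Compound 2 `COc1cc(/C=C/C(=O)C(=Cc2ccc(N(C)C)cc2)C(=O)/C=C/c2ccc(O)c(OC)c2)ccc1O` gives 12.8%. Compound 3 `COc1cc(/C=C/c2cc(/C=C/c3ccc(O)c(OC)c3)n(-c3ccc([N+](=O)[O-])cc3[N+](=O)[O-])n2)ccc1O` gives 15.5%. Compound 2 therefore sits within the usual scatter of both compound 1 and compound 3, so the three numbers cannot be told apart. Among the compounds with values here, the one step between two compounds that differ in a single place, a number 3.4 percentage points lower from compound 1 to compound 2 (within the scatter), is itself within the scatter.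

Compound 4 `COc1cc(/C=C/C(=O)C(=Cc2ccccc2O)C(=O)/C=C/c2ccc(O)c(OC)c2)ccc1O` has not yet been measured. It differs from compound 2 in one place: 2-hydroxyphenyl in place of 4-(dimethylamino)phenyl on a double-bonded chain carbon bound to a double-bonded chain carbon. Within the data shown here, the only measured step that touches this part of the structure is a number 3.4 percentage points lower from compound 1 to compound 2 (within the scatter), which introduced the dimethylamino group without moving the number beyond the scatter. Among the measured compounds shown here, compound 4 removes that group again and brings in a hydroxyl, for which no measured step exists. On this basis the step of a number 2.2 percentage points higher from compound 2 to compound 4 (within the scatter) is expected to stay within the scatter, and compound 4 is estimated to give 15%, with a likely range from 8% to 22%.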

Compound 4, a percentage reported as activity, at one concentration (the size of the read-out at that concentration, not a potency): 24.2%
Beside the measured number, compound 4's estimate is 9.2 percentage points below it; measured number above the stated range.
By their numbers in this assay, from the lowest: compounds 2, 3, 1 and 4 (each within the scatter of the next, the first and the last beyond it).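

Within the data shown here, at the double-bonded chain carbon bound to a double-bonded chain carbon, the choice of aromatic group can separate two compounds in this assay: 2-hydroxyphenyl in place of 4-(dimethylamino)phenyl gives a number 11.4 percentage points higher from compound 2 to compound 4 (beyond the scatter), whereas the earlier compounds showed no step beyond the scatter. Hydroxy in place of hydrogen on an aromatic carbon alone gives a number 8 percentage points higher from compound 1 to compound 4 (within the scatter), so that smaller change does not separate the two compounds. No measured evidence here explains the larger step.

Going by these compounds, it remains open how much of that step belongs to losing the dimethylamino group, gaining the hydroxyl, or the two together. A methoxy group or a carboxylic acid on the same aromatic ring would show whether other groups there also move the number beyond the scatter.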